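Acetamido replacing (cyclohexylcarbonyl)oxy: the half-life of compound 3

The source may hold more compounds than are shown below. What is called first, only, known or untested is meant among the compounds shown, and "the series" means these compounds.

Compound 1 `CC(=O)OC1CCC(CN2CCN(c3cc(=O)c4cc(C(F)(F)F)cc([N+](=O)[O-])c4s3)CC2)CC1` gives < 0.15 h in an ADME assay on cells (Hepatocyte, Homo sapiens) for metabolic stability (on this read-out lower numbers stand for a shorter-lived compound and higher numbers for a longer-lived compound), as a limit of the assay, not a number
Compound 2 `O=C(OC1CCC(CN2CCN(c3cc(=O)c4cc(C(F)(F)F)cc([N+](=O)[O-])c4s3)CC2)CC1)C1CCCCC1` gives 0.0967 h in this assay as a number
Compound 3 `CC(=O)NC1CCC(CN2CCN(c3cc(=O)c4cc(C(F)(F)F)cc([N+](=O)[O-])c4s3)CC2)CC1` is not yet measured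

Among the compounds with values here, compound 2 at 0.0967 h holds the only number so far. For compound 1 the value is a limit, (the limit of < 0.15 h in this assay, at which 1 of the 2 values shown sits), and no number.

Compound 3 differs from compound 2 by acetamido in place of (cyclohexylcarbonyl)oxy on a saturated ring carbon on a saturated ring carbon of a six-membered non-aromatic ring of carbon only. Within the data shown here, the one measured step bearing on this is a step that the limit leaves unreadable from compound 1 to compound 2 and it offers no size to carry forward. The expectation therefore rests on a single number and stays loose. A rise in this assay is expected, of uncertain size, since compound 2 at 0.0967 h leaves little room downward. The expected move is a 3.1-fold higher number from compound 2 to compound 3 (0.49 log units; beyond the scatter) and a result at the limit of the assay would not be a surprise. The estimate for compound 3 is 0.3 h within an expected range from 0.1 h to 1 h as a working figure.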

Compound 3, half-life: > 1.55 h
Compound 3 ended at the assay's limit; the forecaster's own chance of this, stated with the estimate: 25%; middle value at least 5.1-fold (0.71 log units) away from the limit.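

In this assay compound 3 gives > 1.55 h, which is a limit of the assay and not a number. The step between the two acyloxy compounds cannot be read, but acetamido on a saturated ring carbon of a six-membered non-aromatic ring of carbon only now gives two readable steps: an at least 16-fold higher number from compound 2 to compound 3 (1.20 log units; beyond the scatter) against (cyclohexylcarbonyl)oxy and an at least 10-fold higher number from compound 1 to compound 3 (1.01 log units; beyond the scatter) against acetoxy, both large and beyond the scatter, so this position can carry a change that moves the half-life far, and among these three compounds neither acyloxy compound goes against the split between them and the acetamido compound. The data shown give no cause for this split.

As far as these compounds go, the true size of both steps stays open, and so does whether the gain follows the amide hydrogen or the smaller group, as only the acetamido group stands on the nitrogen side of the comparison. A cyclohexylcarbonylamino group would test the large acyl part on the same linkage, and a hydroxyl group or a primary amine on the same ring carbon would show how much of the acyl part is needed at all.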